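The source may report more compounds than this note shows. Statements on the series, on what has been measured and on what is new or still open speak of the compounds shown alone.

Measured so far:
compound 1, `CC1(C)C(=O)N(c2ccc(S(C)(=O)=O)cc2)c2ncccc21`, 42%;
compound 2, `CCCCC1(C)C(=O)N(c2ccccc2)c2ncccc21`, 21%.

In a functional assay on the whole organism (Pleural cavity) for inhibition, with Rattus norvegicus as the target, at a dose of 25 mg/kg (on this read-out lower numbers stand for less inhibition and higher numbers for more inhibition at the one dose given (going by the name of the read-out)), compound 1 stands highest of the two numbers, and compound 2 lies a gap below it that is beyond the scatter. Compound 3, `CC(C)c1ccc(N2C(=O)C(C)(C)c3cccnc32)cc1`, has not yet been measured there. It differs from compound 1 in one place: isopropyl in place of methylsulfonyl on an aromatic carbon. Among the compounds with values here, no measured pair shows this exact change, and compound 2 differs from compound 1 in more than one place, so no step can be read off for it. The change is expected to lower this assay moderately, by a number 12 percentage points lower from compound 1 to compound 3 (beyond the scatter). For compound 3 the value is estimated at 30%, between 10% and 50%.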

Compound 3, a percentage reported as inhibition, in the whole organism at one dose (the size of the read-out at that dose, not a potency): 29%
Compound 3: the middle estimate sits 1 percentage points above what was measured; low and high end bracket the measured number.
By their numbers in this assay, from the lowest: compounds 2 and 3 (each within the scatter of the next); then compound 1.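

In this assay, within the data shown here, the step at this position is the first that can be read in one place: a number 13 percentage points lower from compound 1 to compound 3 (beyond the scatter). It shows that the aromatic carbon para to a large group is sensitive to the exchange of methylsulfonyl for isopropyl, though the step is modest and compound 3 still gives 29%. Nothing at hand accounts for this step.

On these data alone, whether an amine or a carboxylic acid at this carbon would give a value nearer that of compound 1 or compound 3 remains open. So does whether the same step would hold with a butyl chain on the shared core.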